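Swapping One Aryl Group on a Weakly Cytotoxic Compound

The source may hold more compounds than are shown below. What is called first, only, known or untested is meant among the compounds shown, and "the series" means these compounds.

Compound 1 (`Clc1ccc(-c2cc(-c3ccsc3)nc(-c3ccccc3Cl)c2)o1`) gives 17200 nM
Compound 2 (`Clc1ccc(-c2cc(-c3ccco3)nc(-c3cccs3)c2)o1`) gives 16000 nM

Both compounds were tested in a functional assay on K562 cells (Homo sapiens) for cytotoxicity, in the presence of a further agent that is not named here (a higher number here means a weaker inhibitor, a lower number a stronger inhibitor), and their numbers lie within the scatter of each other, so neither can be ranked above the other. Among the measured compounds shown here, compound 1 therefore stands level with compound 2, the only other measured compound. The two also differ in more than one place, so they offer no clean comparison for any single group.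

Compound 3 (`Cc1ccc(-c2cc(-c3ccc(Cl)o3)cc(-c3ccsc3)n2)cc1`) has not yet been measured. It comes from compound 1 by placing 4-methylphenyl where 2-chlorophenyl sits, on an aromatic carbon next to the ring nitrogen (4-methylphenyl in place of 2-chlorophenyl on an aromatic carbon). For the measured compounds named here, no measured pair shows what this swap does, so the best guide is the shared level of compound 1 at 17200 nM and compound 2 at 16000 nM in this assay.

The estimated 1.2-fold lower number from compound 1 to compound 3 (0.09 log units; within the scatter) stays within the usual scatter, so no clear direction is expected. Compound 3 is expected at 14000 nM (estimated range 5000 nM to 40000 nM).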

Compound 3, half-maximal inhibitory concentration: 19900 nM
Estimate against measurement, compound 3: 1.4-fold (0.15 log units) below; the range from low to high includes it.
By their numbers in this assay, from the lowest: compounds 2, 1 and 3 (each within the scatter of the next).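

Placing 4-methylphenyl where 2-chlorophenyl sits, on an aromatic carbon next to the ring nitrogen, gives a 1.2-fold higher number from compound 1 to compound 3 (0.06 log units; within the scatter) in this assay, the first clean reading at this position. Within this single pair, the shared core therefore accepts either of these two substituted phenyl groups with no difference that can be told from the usual scatter of the measurement, although the swap replaces the chlorine with a methyl group and also moves the substituent to another place on the phenyl ring. No measurement on hand accounts for this result.

The pair cannot separate the effect of swapping chlorine for methyl from the effect of moving the substituent, so 2-methylphenyl and 4-chlorophenyl would be needed to pull these two changes apart. As far as these compounds go, it also remains open whether a more different group at this position, such as an amine, a carboxylic acid or a longer chain, would move the number beyond the scatter, since two similar phenyl groups cannot show how far this position tolerates change.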